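Varying the Aryl Group on a Shared Core

A few compounds are considered here, and "the series" means these few. Any claim that something is new, unique, unknown or untested is made for them only; others in the source may bear on it.

Compound 1 `COc1ccc(CO/N=C/c2c(-c3ccc4ccccc4c3)nc3occn23)cc1` gives 4400 nM in an assay on HepG2 cells for agonist activity at nuclear receptor subfamily 1 group I member 3 (Homo sapiens), read by a luciferase reporter, with a stated time of 23 h; a higher number here means that more compound is needed for the effect, a lower number that less compound is needed.
Compound 2 `FC(F)(F)c1ccc(CO/N=C/c2c(-c3ccc4ccccc4c3)nc3occn23)cc1` gives 470 nM in this assay.
Compound 3 `Fc1c(F)c(F)c(CO/N=C/c2c(-c3ccc4ccccc4c3)nc3occn23)c(F)c1F` gives 1700 nM in this assay.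

Among the three measured compounds, compound 3 stands second highest: compound 1 sits above it, by a 2.6-fold lower number from compound 1 to compound 3 (0.41 log units; beyond the scatter) in the reverse direction, and compound 2 sits below it, by a 3.6-fold higher number from compound 2 to compound 3 (0.56 log units; beyond the scatter) read backwards. Compound 4 `Clc1ccccc1CO/N=C/c1c(-c2ccc3ccccc3c2)nc2occn12` has not been measured. It differs from compound 3 in one place: 2-chlorophenyl in place of 2,3,4,5,6-pentafluorophenyl on a saturated chain carbon bound to an oxygen on an unsaturated carbon. Within the data shown here, no measured step swaps in this exact group, so the steps that bear on it are those that exchange the whole aryl group at the same place: a 2.6-fold lower number from compound 1 to compound 3 (0.41 log units; beyond the scatter) and a 3.6-fold higher number from compound 2 to compound 3 (0.56 log units; beyond the scatter), both modest, showing that such exchanges move this assay by moderate amounts in either direction. A step of similar modest size is therefore expected for compound 4, more likely downward than upward, giving a 1.7-fold lower number from compound 3 to compound 4 (0.23 log units; within the scatter). Compound 4 is estimated at 1000 nM, with a range from 300 nM to 3500 nM.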

Compound 4, half-maximal effective concentration: 1100 nM
The estimate for compound 4 lay 1.1-fold (0.04 log units) below the measured number; measured number inside the range.
By their numbers in this assay, from the lowest: compound 2; then compounds 4 and 3 (each within the scatter of the next); then compound 1.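

In this assay, placing 2-chlorophenyl on this saturated chain carbon gives a result that cannot be told apart from the pentafluorophenyl one (a 1.5-fold lower number from compound 3 to compound 4 (0.19 log units; within the scatter)), so one chlorine and five fluorines on the ring serve equally here. Compound 4 still stands clearly apart from the other two (a 2.3-fold higher number from compound 2 to compound 4 (0.37 log units; beyond the scatter); a 4.0-fold lower number from compound 1 to compound 4 (0.60 log units; beyond the scatter)), leaving compound 2, with 4-(trifluoromethyl)phenyl, lowest and compound 1, with 4-methoxyphenyl, highest of the four. No measurement at hand explains why the aryl groups fall in this order.

Going by these compounds, how much of the result for compound 4 comes from the chlorine itself remains open, and an unsubstituted phenyl or a bromine in its place would test that. On these data alone, whether an amine or a carboxylic acid on this ring would fit the same order also remains unknown.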